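This account rests on a few compounds, and the source may have more. Where it says the series, first, only, none or still open, it means among the compounds named here.

Measured so far in a functional assay on HL-60 cells (Homo sapiens) for antiproliferative activity, read by sulforhodamine B assay, with a stated time of 72 h; a lower number here means a stronger inhibitor, a higher number a weaker inhibitor:
- compound 1 `Cc1cc(C)nc(NS(=O)(=O)c2ccc(Nc3nncc4ccccc34)cc2)n1`: 9.5 nM
- compound 2 `C(=C/c1ccccc1)\C(=N\Nc1nncc2ccccc12)c1ccccc1`: 4.7 nM
- compound 3 `S=C(NNc1nncc2ccccc12)Nc1ccccc1`: 95 nM

Compound 2 holds the lowest number of the three in this assay, and its gaps to the other two lie beyond the scatter. Compound 1 is its nearest neighbour, while compound 3 sits furthest away.

The next compound to be tested is compound 4 `Clc1ccc(C(/C=C/c2ccccc2)=N\Nc2nncc3ccccc23)cc1`. It keeps compound 2 intact except for chloro in place of hydrogen on an aromatic carbon, para to a large group, so that a phenyl becomes a 4-chlorophenyl: chloro in place of hydrogen on an aromatic carbon.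

Within the data shown here, no two measured compounds differ in one place, so the data give no direct precedent for this change. The working expectation is therefore a small step in this assay, with no direction favoured and nothing beyond the scatter. The three values spread widely on the shared core, with compound 3 at 95 nM the highest number, so the range is kept wide and reaches further upward than downward. The estimated step is a 1.1-fold higher number from compound 2 to compound 4 (0.03 log units; within the scatter). For compound 4 the expected value is 5 nM, with an estimated range of 1.5 nM to 18 nM.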

Compound 4, half-maximal inhibitory concentration: 7.4 nM
The estimate for compound 4 lay 1.5-fold (0.17 log units) below the measured number; measured number inside the range.
By their numbers in this assay, from the lowest: compounds 2, 4 and 1 (each within the scatter of the next, the first and the last beyond it); then compound 3.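

Among these compounds, this is the first single-place comparison: in this assay, the change from phenyl to 4-chlorophenyl gives a 1.6-fold higher number from compound 2 to compound 4 (0.20 log units; within the scatter) and so leaves the read-out of the parent within the usual scatter of repeated measurements. At this aromatic carbon, para to a large group, chloro in place of hydrogen is therefore tolerated without a measurable loss, and adding this one heavy atom does not separate the two compounds in this assay. No supporting measurement is available to explain the size of this step.

The compounds shown leave open whether this tolerance extends beyond chloro, for example to a methoxy group, an amine or a carboxylic acid at the same carbon, any of which could show whether this position accepts larger or charged groups as readily. They also leave open whether chloro on the other phenyl of compound 2 would give a similar result, so the present step describes one substituent at one position and cannot yet be read as a trend across the series.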